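The compounds below may be only part of what the source reports. "The series", "measured", "known", "first", "only" and "open" are said of these compounds alone.

Measured compounds:
compound 1, `Cc1cc(F)ccc1/C=C(/SCc1ccc(F)cc1)C(=O)c1ccc(Br)cc1` — 10000 nM
compound 2, `O=C(/C(=C\c1ccc(F)cc1C(F)(F)F)SCc1ccc(F)cc1)c1ccc(Br)cc1` — 10000 nM
compound 3, `Cc1ccc(S/C(=C/c2ccc(C)s2)C(=O)c2ccc(Br)cc2)cc1` — > 100000 nM

Compound 1, `Cc1cc(F)ccc1/C=C(/SCc1ccc(F)cc1)C(=O)c1ccc(Br)cc1`, was tested in a functional assay on DU-145 cells (Homo sapiens) for inhibition, read by trypan blue exclusion, with a stated time of 96 h (a lower number here means a stronger inhibitor of growth, a higher number a weaker inhibitor of growth), where compound 1 gives 10000 nM. Compound 2, `O=C(/C(=C\c1ccc(F)cc1C(F)(F)F)SCc1ccc(F)cc1)c1ccc(Br)cc1`, gives 10000 nM in this assay, so compound 1 and compound 2 stand level at the digits shown. For compound 3, `Cc1ccc(S/C(=C/c2ccc(C)s2)C(=O)c2ccc(Br)cc2)cc1`, this assay reports only a limit, > 100000 nM, and not a number; this is the limit of > 100000 nM in this assay, at which 1 of the 3 values shown sits.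

The step now followed leads from compound 1 to compound 4, `Cc1cc(C)cc(/C=C(/SCc2ccc(F)cc2)C(=O)c2ccc(Br)cc2)c1`, which has not yet been measured in this assay. The change is 3,5-dimethylphenyl in place of 4-fluoro-2-methylphenyl on a double-bonded chain carbon bound to a double-bonded chain carbon.

Within the data shown here, the only step between measured compounds that differ in one place is no change at the digits printed from compound 1 to compound 2 (within the scatter); it also alters a substituent on the aryl group on the double-bonded chain carbon and falls within the scatter. Among the measured compounds shown here, compound 3 changes more than one place at once and gives only a limit, so it offers no measured step. On this evidence, compound 4 is expected to give a value close to that of compound 1, with the step of no change at the digits printed from compound 1 to compound 4 (within the scatter) estimated to lie within the scatter. Compound 4 is thus expected to give about 10000 nM in this assay, within a range from 3000 nM to 40000 nM.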

Compound 4, concentration for 50% growth inhibition: 10000 nM
For compound 4 middle estimate and measured number coincide at the digits printed, within the range that was stated.
By their numbers in this assay, from the lowest: compounds 1, 2 and 4 (each within the scatter of the next). At a limit, above all of these: compound 3.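

In this assay the replacement of 4-fluoro-2-methylphenyl by 3,5-dimethylphenyl on a double-bonded chain carbon bound to a double-bonded chain carbon gives no change at the digits printed from compound 1 to compound 4 (within the scatter). The earlier step exchanged only methyl for trifluoromethyl on the aromatic ring, whereas this one swaps the whole substituted phenyl group and the entering group carries no fluorine, so the level of compound 1 now also stands for a broader change at this place. No measured property among the data shown bears on this result.

The compounds shown leave open whether this place would tolerate an aryl group bearing an amine or a carboxylic acid, as all three aryl groups compared here carry only methyl, trifluoromethyl or fluorine. They also leave open how an unsubstituted phenyl group would compare with compound 1 in this assay.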